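Amino for chloro on the purine core of compound 1

The source may report more compounds than this note shows. Statements on the series, on what has been measured and on what is new or still open speak of the compounds shown alone.

Measured so far:
compound 1, `ClCc1ccccc1Cn1cnc2c(Cl)nc(Cl)nc21`: 3310 nM
compound 2, `ClCc1cccc(Cn2cnc3nc(Cl)nc(Cl)c32)c1`: 30900 nM

Of the compounds shown here, two have been tested in a functional assay on IGROV-1 cells (Homo sapiens) for cytotoxicity, read by sulforhodamine B assay, with a stated time of 48 h; a higher number here means a weaker inhibitor of growth, a lower number a stronger inhibitor of growth. Compound 1 gives 3310 nM, the lower of the two numbers, and so the stronger inhibitor of growth. Compound 2 gives 30900 nM, a gap that lies beyond the usual scatter of such measurements.

Compound 3, `Nc1nc(Cl)c2ncn(Cc3ccccc3CCl)c2n1`, has not yet been measured. It differs from compound 1 in one place: amino in place of chloro on an aromatic carbon. Among the measured compounds shown here, no pair of measured compounds shows what such a change does here, so no measured step can guide the expectation.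

For compound 3 the expected step is a 1.7-fold higher number from compound 1 to compound 3 (0.22 log units; within the scatter), a small shift towards a weaker inhibitor, close to the edge of the scatter. Compound 3 is therefore estimated at 5500 nM in this assay, with a range from 1500 nM to 20000 nM.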

Compound 3, concentration for total growth inhibition: > 100000 nM
Compound 3 gave a limit, no number (the forecaster's own chance of this, stated with the estimate: 5%); middle value at least 18-fold (1.25 log units) from the limit.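

In this assay compound 3 gives > 100000 nM, which is a limit of the assay and not a number. Among the compounds shown here, until now no measured pair showed what a change at this position does, and the first such pair reveals a large effect, with amino in place of chloro on the aromatic carbon between two ring nitrogen atoms giving an at least 30-fold higher number from compound 1 to compound 3 (1.48 log units; beyond the scatter). So growth inhibition in this series depends strongly on what sits at this position, and the true size of the loss stays unknown, since the reading ends at a limit: the limit of > 100000 nM in this assay, at which 1 of the 3 values shown sits.

The compounds shown do not tell why amino has this effect, nor whether a different group here, such as methoxy or a methylamino group, would keep the inhibition of compound 1. As far as these compounds go, whether the same change would act alike on compound 2 also stays open.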